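A few compounds are considered here, and "the series" means these few. Any claim that something is new, unique, unknown or untested is made for them only; others in the source may bear on it.

Measured in the series:
- compound 1 `C[C@]1(C(=O)O)CC[C@H](C(=O)N2CC[C@](c3ccc(C(F)(C(F)(F)F)C(F)(F)F)cc3)(S(=O)(=O)c3ccc(F)cc3)C2)CC1`, 93%
- compound 3 `O=C([C@H]1CC[C@H](c2nnn[nH]2)CC1)N1CC[C@](c2ccc(C(F)(C(F)(F)F)C(F)(F)F)cc2)(S(=O)(=O)c2ccc(F)cc2)C1`, 73%
- compound 2 `CCC[C@]1(C(=O)N2CC[C@](c3ccc(C(F)(C(F)(F)F)C(F)(F)F)cc3)(S(=O)(=O)c3ccc(F)cc3)C2)CC[C@H](C(=O)O)CC1`, "not determined" (no result reported)

The read-out is an ADME assay on microsomes from liver (Mus musculus) for metabolic stability, with a stated time of 10 min; a higher number here means that more of the compound is left, a lower number that less of the compound is left. In this assay compound 1 gives 93% and compound 3 gives 73%. Among the measured compounds shown here, compound 2 has no number in this assay, so only two values can be compared. Of these, compound 1 stands highest; the step of a number 20 percentage points lower from compound 1 to compound 3 (beyond the scatter) is beyond the scatter.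

Compound 4 `NC(=O)[C@H]1CC[C@H](C(=O)N2CC[C@](c3ccc(C(F)(C(F)(F)F)C(F)(F)F)cc3)(S(=O)(=O)c3ccc(F)cc3)C2)CC1` is not yet measured. It differs from compound 1 in one place: 4-carbamoylcyclohexyl in place of 4-carboxy-4-methylcyclohexyl on a carbonyl carbon.

For the measured compounds named here, only one measured step bears on this change. The step from compound 1 to compound 3 also replaces the 4-carboxy-4-methylcyclohexyl group on the same carbonyl carbon, there by 4-(1H-tetrazol-5-yl)cyclohexyl, and this lowered the value by a number 20 percentage points lower from compound 1 to compound 3 (beyond the scatter). The change to compound 4 is of the same kind, a different group on the ring in place of the carboxylic acid and methyl, so a drop of comparable size is expected rather than none. The expectation for compound 4 is therefore a step of a number 15 percentage points lower from compound 1 to compound 4 (beyond the scatter) from compound 1, downward. Compound 4 is estimated at 78%, in the range 60% to 93%.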

Compound 4, percent of the compound remaining: 100%
Beside the measured number, compound 4's estimate is 22 percentage points below it, and the stated range ends below it.
By their numbers in this assay, from the lowest: compound 3; then compounds 1 and 4 (each within the scatter of the next).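

In this assay, 4-carbamoylcyclohexyl in place of 4-carboxy-4-methylcyclohexyl on the carbonyl carbon gives a number 7 percentage points higher from compound 1 to compound 4 (within the scatter), so the carboxylic acid and its methyl group can both leave this position without a change that stands out from the scatter. Carbamoyl in place of 1H-tetrazol-5-yl on the saturated ring carbon gives a number 27 percentage points higher from compound 3 to compound 4 (beyond the scatter), and with a number 20 percentage points lower from compound 1 to compound 3 (beyond the scatter) this shows that the loss seen earlier does not follow from every replacement of 4-carboxy-4-methylcyclohexyl: among the compounds shown, it stands with the tetrazole-bearing group of compound 3 alone. No available measurement explains why the carbamoyl and tetrazole groups part in this way.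

Compound 1 and compound 4 differ in both the carboxylic acid or carbamoyl group and the methyl group, so the contribution of each remains unresolved without a plain 4-carboxycyclohexyl group or a carbamoyl group carried together with the methyl. Steps involving compound 2 cannot be read, which leaves the longer propyl chain open, and how a nitrile or an amine on the saturated ring would behave also remains unknown.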